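The compounds below may be only part of what the source reports. "The series", "measured", "known", "first", "only" and "open" are said of these compounds alone.

Of the compounds shown here, three of a shared core have been measured in a toxicity assay on MRC5 cells (Homo sapiens) for inhibition, read by MTT assay, with a stated time of 72 h (a lower number here means a stronger inhibitor, a higher number a weaker inhibitor), and a fourth awaits its number. Compound 1 `N#Cc1ccccc1-n1cc(COc2cccc(NC(=O)Nc3ccc(Cl)c(C(F)(F)F)c3)c2)nn1` gives 17500 nM. Compound 2 `N#Cc1cccc(-n2cc(COc3cccc(NC(=O)Nc4ccc(Cl)c(C(F)(F)F)c4)c3)nn2)c1` gives 2960 nM. Compound 3 `O=C(Nc1cccc(OCc2cn(-c3ccc(Br)cc3)nn2)c1)Nc1ccc(Cl)c(C(F)(F)F)c1` gives 11000 nM. Of these three numbers, compound 2 holds the lowest: compound 3 is nearest, with a 3.7-fold higher number from compound 2 to compound 3 (0.57 log units; beyond the scatter), and compound 1 is furthest, with a 5.9-fold lower number from compound 1 to compound 2 (0.77 log units; beyond the scatter) read in reverse.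

Compound 4 `O=C(Nc1cccc(OCc2cn(-c3ccc(I)cc3)nn2)c1)Nc1ccc(Cl)c(C(F)(F)F)c1` differs from compound 2 in a single place: 4-iodophenyl in place of 3-cyanophenyl on an aromatic nitrogen. The closest comparison in hand is compound 3, which carries a 4-bromophenyl on the same aromatic nitrogen where compound 2 carries a 3-cyanophenyl, and that step, a 3.7-fold higher number from compound 2 to compound 3 (0.57 log units; beyond the scatter), lay beyond the scatter. The other step between compounds bearing a 4-bromophenyl and a cyanophenyl, a 1.6-fold lower number from compound 1 to compound 3 (0.20 log units; within the scatter), stayed within the scatter, so the 3-cyanophenyl of compound 2 stands apart from both neighbours. With a 4-iodophenyl entering in place of that 3-cyanophenyl, the expected move for compound 4 is a modest step upward, a 3.4-fold higher number from compound 2 to compound 4 (0.53 log units; beyond the scatter), close to what compound 3 showed. Compound 4 is therefore estimated at 10000 nM, with a likely range from 4000 nM to 25000 nM.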

Compound 4, half-maximal inhibitory concentration: 6840 nM
Compound 4: middle estimate off by 1.5-fold (0.16 log units), on the high side, within the range that was stated.
By their numbers in this assay, from the lowest: compound 2; then compounds 4, 3 and 1 (each within the scatter of the next, the first and the last beyond it).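

In this assay, for the compounds shown here, iodo in place of bromo on the aromatic carbon (a 1.6-fold lower number from compound 3 to compound 4 (0.21 log units; within the scatter)) is the first step at this position that keeps the phenyl ring and the place of its substituent and alters only the substituent's atom, and the 4-bromophenyl and 4-iodophenyl groups cannot be told apart by it. The 3-cyanophenyl of compound 2 now stands apart from a second halogen-bearing phenyl as well (a 2.3-fold higher number from compound 2 to compound 4 (0.36 log units; beyond the scatter)), so its lowest number among these compounds no longer rests on the comparison with compound 3 alone. The 2-cyanophenyl of compound 1 is separated from the 4-iodophenyl (a 2.6-fold lower number from compound 1 to compound 4 (0.41 log units; beyond the scatter)) but not from the 4-bromophenyl (a 1.6-fold lower number from compound 1 to compound 3 (0.20 log units; within the scatter)), even though the two halogen compounds sit within the scatter of each other, so that end of the series has no sharp edge.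

No measurement shown here explains why these aryl groups differ in this assay. Also open, going by these compounds, is how a 4-cyanophenyl, or a phenyl carrying an amine or a carboxylic acid, would read on that aromatic nitrogen.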